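Shifting a methylphenyl group on the core of compound 1

This account rests on a few compounds, and the source may have more. Where it says the series, first, only, none or still open, it means among the compounds named here.

Compound 1 `Cc1ccccc1C(=O)n1c(-c2cn(-c3ccccc3)nc2-c2ccc(F)cc2)nc2ccccc21` and compound 3 `Cc1ccc(C(=O)n2c(-c3cn(-c4ccccc4)nc3-c3ccc(F)cc3)nc3ccccc32)cc1` share one core. Among the compounds with values here, in an ADME assay on HEK-293T cells (Homo sapiens) for cytotoxicity, read by MTT assay, with a stated time of 24 h (on this read-out lower numbers stand for higher toxicity in this test and higher numbers for lower toxicity in this test), compound 1 gives 189000 nM, the lowest of the two numbers known here, though compound 2 `Cc1ccc(-c2nn(-c3ccccc3)cc2-c2nc3ccccc3n2C(=O)c2cccc(C)c2)cc1` gives 195000 nM, which lies within the usual scatter of that value. Compound 3 carries 4-methylphenyl in place of 2-methylphenyl on a carbonyl carbon. Within the data shown here, no measured pair differing in one place exists, so no step size is known in this assay. With both measured compounds this close together, the step is expected to be small, a 1.0-fold higher number from compound 1 to compound 3 (0.00 log units; within the scatter), not beyond the scatter. Compound 3 is therefore expected to give 190000 nM, between 95000 nM and 380000 nM.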

Compound 3, half-maximal cytotoxic concentration: 178000 nM
Estimate against measurement, compound 3: 1.1-fold (0.03 log units) above, and the stated range covers the measured number.
By their numbers in this assay, from the lowest: compounds 3, 1 and 2 (each within the scatter of the next).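

In this assay, 4-methylphenyl in place of 2-methylphenyl on a carbonyl carbon gives a 1.1-fold lower number from compound 1 to compound 3 (0.03 log units; within the scatter), the first step known at this place. For this one change, compound 1 and compound 3 cannot be told apart in this test, so shifting the methyl group on this phenyl ring leaves the number within the scatter. Nothing available here gives a reason for this result. The compounds shown leave open whether an amine or a carboxylic acid in place of the methyl group would give a step beyond the scatter.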